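Swapping a Branched Chain for a Trifluoromethylbenzyl Group

A few compounds are considered here, and "the series" means these few. Any claim that something is new, unique, unknown or untested is made for them only; others in the source may bear on it.

Of the compounds shown here, three sharing one core have been tested in an assay on Prostate gland for inhibition of steroid 5-alpha-reductase (Rattus norvegicus); a higher number here means a weaker inhibitor, a lower number a stronger inhibitor. Compound 1 `CCC(C)n1ccc2cc(/C(C)=C/C(=O)Nc3ccccc3OCCCC(=O)O)ccc21` gives 67 nM, compound 2 `CCCCC(C)n1ccc2cc(/C(C)=C/C(=O)Nc3ccccc3OCCCC(=O)O)ccc21` gives 6 nM, and compound 3 `CCCCCC(CCCCC)n1ccc2cc(/C(C)=C/C(=O)Nc3ccccc3OCCCC(=O)O)ccc21` gives 25 nM. Compound 3 therefore stands second highest of the three numbers, above compound 2 and below compound 1. The steps that changed the group on the aromatic nitrogen moved the numbers noticeably: an 11-fold lower number from compound 1 to compound 2 (1.05 log units; beyond the scatter), a 2.7-fold lower number from compound 1 to compound 3 (0.43 log units; beyond the scatter), and a 4.2-fold higher number from compound 2 to compound 3 (0.62 log units; beyond the scatter).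

Compound 4 `C/C(=C\C(=O)Nc1ccccc1OCCCC(=O)O)c1ccc2c(ccn2Cc2ccc(C(F)(F)F)cc2)c1` differs from compound 3 at the same position: 4-(trifluoromethyl)benzyl in place of 1-pentylhexyl on an aromatic nitrogen. Among the compounds with values here, none of the measured steps exchanges a chain for a ring at this position, so the earlier steps only show that this position tolerates sizeable changes, with all three numbers falling within a span of about one order. Compound 4 is expected to land near the middle of that span, with a 1.7-fold lower number from compound 3 to compound 4 (0.22 log units; within the scatter) as the estimated step. The estimate for compound 4 in this assay is 15 nM, within a range from 3 nM to 80 nM.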

Compound 4, half-maximal inhibitory concentration: 300 nM
For compound 4 the middle estimate is 20-fold (1.30 log units) below the measured one, and the stated range ends below it.
By their numbers in this assay, from the lowest: compound 2; then compound 3; then compound 1; then compound 4.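

In this assay, the result shows that this position on the aromatic nitrogen does not treat groups of similar size alike: 1-pentylhexyl and 4-(trifluoromethyl)benzyl have the same number of heavy atoms, yet the exchange gives a 12-fold higher number from compound 3 to compound 4 (1.08 log units; beyond the scatter) and costs far more than any change among the chains. The benzyl group also falls behind the two smaller branched chains, with a 50-fold higher number from compound 2 to compound 4 (1.70 log units; beyond the scatter) and a 4.5-fold higher number from compound 1 to compound 4 (0.65 log units; beyond the scatter) as the steps, which makes compound 4 the weakest inhibitor of the four. Nothing available here gives a reason for this loss.

Still open, going by these compounds, is whether the aromatic ring or the trifluoromethyl group on it accounts for the higher number, a question that a plain benzyl group could help to settle. A cyclohexylmethyl group would likewise show whether a saturated ring fares better at this position.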